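Fluoro in Place of Tert-Butyl: Expecting Compound 4

The source may hold more compounds than are shown below. What is called first, only, known or untested is meant among the compounds shown, and "the series" means these compounds.

Compound 1: `CC(C)(C)c1cc(N)c2cc(NC(=O)/C=C/c3ccc(C(F)(F)F)cc3)ccc2n1` — 0.3 nM
Compound 2: `CCCc1cc(N)c2cc(NC(=O)/C=C/c3ccc(C(C)(C)C)cc3)ccc2n1` — 22 nM
Compound 3: `CCCc1cc(NC2CC2)c2cc(NC(=O)/C=C/c3ccc(C(F)(F)F)cc3)ccc2n1` — 40 nM

In an assay on isolated protein for displacement of a labelled ligand from melanin-concentrating hormone receptor 1 (Homo sapiens) (on this read-out lower numbers stand for stronger inhibition and higher numbers for weaker inhibition), compound 2 gives 22 nM, the second highest of the three numbers. Its nearest neighbour is compound 3, which gives 40 nM, a gap within the scatter. Its furthest neighbour is compound 1, which gives 0.3 nM, a gap well beyond the scatter. Compound 4, `CCCc1cc(N)c2cc(NC(=O)/C=C/c3ccc(F)cc3)ccc2n1`, has not been measured. It differs from compound 2 in one place: fluoro in place of tert-butyl on an aromatic carbon. Going by the values given here, no step between measured compounds follows this exact change, so its size is uncertain. A modest loss, or none beyond the scatter, is the expected outcome, and the step of a 2.3-fold higher number from compound 2 to compound 4 (0.36 log units; beyond the scatter) is the estimate. Compound 4 is expected to give 50 nM, within a range from 10 nM to 250 nM.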

Compound 4, half-maximal inhibitory concentration: 130 nM
For compound 4 the middle estimate is 2.6-fold (0.41 log units) below the measured one; the measured number falls inside the stated range.
By their numbers in this assay, from the lowest: compound 1; then compounds 2 and 3 (each within the scatter of the next); then compound 4.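

Going by these compounds alone, putting fluoro in place of tert-butyl on this aromatic carbon gives a 5.9-fold higher number from compound 2 to compound 4 (0.77 log units; beyond the scatter) in this assay and so shows, as the earlier compounds could not, that binding responds to the group at this position. In this pair, going from 4 heavy atoms to 1 costs a modest amount, but a loss beyond the scatter. Nothing measured here accounts for the step.

The compounds shown leave open how a chloro or methoxy group would fare at this position. They also leave open whether the same step would hold on the core of compound 1.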